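One Chlorine Fewer: An Expected Shift in Lipophilicity

The source may report more compounds than this note shows. Statements on the series, on what has been measured and on what is new or still open speak of the compounds shown alone.

Of the compounds shown here, two have been measured so far. Compound 1 `Cc1cc(Oc2ccc(/C=N/NC(=S)Nc3ccc(F)cc3)cc2)ccc1Cl` gives, in a physicochemical assay for lipophilicity, in phosphate buffer, measured as octanol-water partition, with a stated time of 24 h (a higher number here means a more lipophilic compound, a lower number a more polar compound), a value of 6.07. Compound 2 `O=[N+]([O-])c1ccc(Oc2ccc(/C=N/NC(=S)Nc3ccc(Br)cc3)cc2)cc1` gives in this assay a value of 5.68. Of these two numbers compound 1 holds the higher one, and the gap between compound 1 and compound 2 lies beyond the usual scatter of this kind of measurement. The two compounds differ in several places at once, so their pair reveals nothing about any single change.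

Compound 3 `Cc1ccc(Oc2ccc(/C=N/NC(=S)Nc3ccc(F)cc3)cc2)cc1` has not yet been measured. It arises from compound 1 through one change: 4-methylphenyl in place of 4-chloro-3-methylphenyl on an oxygen on an aromatic ring. The part that leaves carries a chlorine; the part that enters does not. Within the data shown here, no measured pair in this set shows the effect of such a change on its own, so the expectation rests on the structures alone. A downward step beyond the scatter is expected, estimated as a number 0.67 log units lower from compound 1 to compound 3 (beyond the scatter) in this assay. Compound 3 is therefore expected to give about 5.4 in this assay, within a range from 5 to 5.8.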

Compound 3, partition coefficient: 5.48
The estimate for compound 3 lay 0.08 log units below the measured number; the measured number falls inside the stated range.
By their numbers in this assay, from the lowest: compounds 3 and 2 (each within the scatter of the next); then compound 1.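

Among these compounds, this pair is the first in the set to isolate a single place, and it shows that the aromatic ring on the oxygen is not a silent part of the molecule: with the rest of compound 1 unchanged, placing 4-methylphenyl where 4-chloro-3-methylphenyl stood gives, in this assay, a number 0.59 log units lower from compound 1 to compound 3 (beyond the scatter) as the step. The change is also more than the loss of a chlorine, since the methyl does not hold the same position in the group that leaves, 4-chloro-3-methylphenyl, as in the group that enters, 4-methylphenyl, so this one step covers both differences and cannot be divided between them. No independent measurement is available to explain why the number moves as it does.

The compounds shown leave open how much of the step belongs to the chlorine and how much to the methyl, which a ring such as 4-chlorophenyl or 3-methylphenyl in the same place could help to separate. They also leave open what an amine or a carboxylic acid on this ring would do to the number, and whether the same swap would give a similar step with a bromine in place of the fluorine on the other end of the molecule.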